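The compounds below may be only part of what the source reports. "The series", "measured", "known", "first", "only" and "open" are said of these compounds alone.

Measured so far in a physicochemical assay for solubility, read by HPLC, at pH 7.4; a higher number here means a more soluble compound, a lower number a less soluble compound:
- Compound 1 `CCCCCCCc1cc(=O)c2cc([N+](=O)[O-])ccc2[nH]1`: < 5000 nM, a limit of the assay and not a number
- Compound 2 `CCCCCCCc1[nH]c2ccc([N+](=O)[O-])cc2c(=O)c1C(=O)OCC`: 5000 nM
- Compound 3 `CCCCCCCc1[nH]c2ccccc2c(=O)c1C(=O)O`: 15000 nM

Compound 3, at 15000 nM, has the higher of the two true numbers. Compound 2 stands lower at 5000 nM, a gap beyond the usual scatter.

Compound 4 `CCCCCCCc1[nH]c2ccc([N+](=O)[O-])cc2c(=O)c1C(=O)O` is compound 3 with nitro in place of hydrogen on an aromatic carbon. Going by the values given here, the only measured step is a number no lower from compound 1 to compound 2 (the limit leaves the size open). On these data alone, it concerns ethoxycarbonyl rather than nitro, and its size stays open because of the limit of < 5000 nM in this assay, at which 1 of the 3 values shown sits. Among the compounds with values here, no measured step therefore isolates the nitro change. The nearest guide is compound 2, which also carries nitro and reads 5000 nM, although it also has ethoxycarbonyl where compound 3 has its acid. Compound 1 also carries nitro, and its < 5000 nM is a limit.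

A moderate fall in this assay is therefore expected, with wide uncertainty, and the expected change is a 1.9-fold lower number from compound 3 to compound 4 (0.27 log units; within the scatter). For compound 4 the estimate is 8000 nM, with an expected range of 3500 nM to 18000 nM.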

Compound 4, solubility: 15000 nM
Estimate against measurement, compound 4: 1.9-fold (0.27 log units) below, and the stated range covers the measured number.
By their numbers in this assay, from the lowest: compound 2; then compounds 3 and 4 (each within the scatter of the next).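

In this assay, going by these compounds alone, the nitro change stands alone for the first time, on the same aromatic carbon and with the carboxy group kept, and it shows no change at the digits printed from compound 3 to compound 4 (within the scatter). With nitro present, hydrogen in place of ethyl on an oxygen next to a carbonyl group gives a 3.0-fold higher number from compound 2 to compound 4 (0.48 log units; beyond the scatter), and bringing in the carboxy group gives an at least 3.0-fold higher number from compound 1 to compound 4 (0.47 log units; beyond the scatter). Compound 1 stands at a limit of the assay and not at a number, so the second of these steps has no upper size: the limit of < 5000 nM in this assay, at which 1 of the 4 values shown sits.

On these data alone, whether the same reading would hold with an amine or a chlorine atom in place of nitro, or with nitro at another carbon of that ring, stays open. Also open, as far as these compounds go, is how this assay would read with a shorter chain, or with an amide in place of the carboxylic acid.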